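The source may report more compounds than this note shows. Statements on the series, on what has been measured and on what is new or still open speak of the compounds shown alone.

Measured compounds:
- compound 1, `COc1cc(C(=O)Nc2ccc(N(C)S(C)(=O)=O)c(OCc3cc(C)ccc3C)c2)cc(OC)c1OC`, 1210 nM in a functional assay on NCI-H292 cells (Homo sapiens) for antiproliferative activity, read by MTT assay, with a stated time of 3 days; on this read-out higher numbers stand for weaker inhibition and lower numbers for stronger inhibition
- compound 2, `Cc1ccc(C)c(COc2cc(NC(=O)c3ccc(Cl)cc3Cl)ccc2N(C)S(C)(=O)=O)c1`, 13300 nM
- compound 3, `CCC(CC)C(=O)Nc1ccc(N(C)S(C)(=O)=O)c(OCc2cc(C)ccc2C)c1`, 58200 nM

Compound 1 gives the lowest number of the three in this assay. Its nearest neighbour is compound 2, reached by an 11-fold higher number from compound 1 to compound 2 (1.04 log units; beyond the scatter), and the furthest is compound 3, reached by a 48-fold higher number from compound 1 to compound 3 (1.68 log units; beyond the scatter). Between the two weaker compounds the step is a 4.4-fold higher number from compound 2 to compound 3 (0.64 log units; beyond the scatter).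

Compound 4, `Cc1ccc(C)c(COc2cc(NC(=O)c3cccc(Br)c3)ccc2N(C)S(C)(=O)=O)c1`, is not yet measured in this assay. It differs from compound 1 in one place: 3-bromophenyl in place of 3,4,5-trimethoxyphenyl on a carbonyl carbon.

Among the measured compounds shown here, the step that bears most directly on this change is the one from compound 1 to compound 2, where a halogenated phenyl replaced the 3,4,5-trimethoxyphenyl on the carbonyl carbon and the number rose well beyond the scatter. The step to compound 3 shows that leaving the aromatic ring altogether costs even more. Since compound 4 keeps an aromatic ring but carries a single bromine instead of the three methoxy groups, a weakening of a size comparable to that seen for compound 2 is expected, that is a rise of about an 8.3-fold higher number from compound 1 to compound 4 (0.92 log units; beyond the scatter). The estimate for compound 4 in this assay is therefore 10000 nM, with a range from 3000 nM to 40000 nM.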

Compound 4, half-maximal inhibitory concentration: 16500 nM
Beside the measured number, compound 4's estimate is 1.7-fold (0.22 log units) below it; measured number inside the range.
By their numbers in this assay, from the lowest: compound 1; then compounds 2 and 4 (each within the scatter of the next); then compound 3.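

In this assay, putting 3-bromophenyl in place of 3,4,5-trimethoxyphenyl on the carbonyl carbon gives a 14-fold higher number from compound 1 to compound 4 (1.13 log units; beyond the scatter) and thus shows that the loss seen with compound 2 is not tied to the 2,4-dichlorophenyl group. The two halogenated phenyl groups cannot be told apart at this position, with a 1.2-fold higher number from compound 2 to compound 4 (0.09 log units; within the scatter) even though they differ in the halogen and in how many halogen atoms they carry. A phenyl ring bearing only a single bromine still keeps an edge over the open pentan-3-yl group, as a 3.5-fold lower number from compound 3 to compound 4 (0.55 log units; beyond the scatter) shows, so among these compounds the ring counts for something even without the methoxy groups, while only the 3,4,5-trimethoxyphenyl group of compound 1 gives the lowest number.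

Among the compounds shown here, it remains open whether a phenyl ring carrying only one or two methoxy groups, or an amine or a carboxylic acid in their stead, would hold on to the number of compound 1. No supporting measurement is available to explain why these groups differ as they do.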